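From chloro to iodo on compound 3

This account rests on a few compounds, and the source may have more. Where it says the series, first, only, none or still open, it means among the compounds named here.

Measured so far in a functional assay on the whole organism with Rattus norvegicus as the target (a higher number here means that more compound is needed for the effect, a lower number that less compound is needed), are three compounds:
Compound 1 `CC(=O)Oc1ccc(-c2ccccc2)cc1C(=O)O` gives 170 mg/kg here
Compound 2 `CCCCOC(=O)Oc1ccc(-c2ccc(F)cc2)cc1C(=O)O` gives 25 mg/kg here
Compound 3 `O=C(O)c1cc(-c2ccc(Cl)cc2)ccc1O` gives 24 mg/kg here

Compound 3 and compound 2 lie within the usual scatter of each other, and compound 3 needs clearly less than compound 1. Compound 4 `O=C(O)c1cc(-c2ccc(I)cc2)ccc1O` alters compound 3 in one place: iodo in place of chloro on an aromatic carbon with iodo in place of chloro on an aromatic carbon. Among the compounds with values here, no measured pair shows this swap alone, so the data give no direct guide. With no evidence for a shift, no change beyond the scatter is expected in either direction. The estimated 1.2-fold higher number from compound 3 to compound 4 (0.07 log units; within the scatter) is therefore small. For compound 4 the estimate in this assay is 28 mg/kg with an expected range from 11 mg/kg to 70 mg/kg in repeated measurements.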

Compound 4, dose for half-maximal effect: 120 mg/kg
Estimate against measurement, compound 4: 4.3-fold (0.63 log units) below; the measured number lies above the stated range.
By their numbers in this assay, from the lowest: compounds 3 and 2 (each within the scatter of the next); then compounds 4 and 1 (each within the scatter of the next).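

In this assay iodo in place of chloro on this aromatic carbon, para to a large group, costs clearly more compound for the effect (a 5.0-fold higher number from compound 3 to compound 4 (0.70 log units; beyond the scatter)). So this position is sensitive to which group it carries, even though the swap exchanges one heavy atom for one heavy atom, with no hydrogen-bond donors or acceptors and no net charge on either side. Nothing available explains this shift. Still open, from the compounds shown here alone, is whether bromo at this place would behave more like chloro or like iodo, and how an amine there would compare.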